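Shifting the Methyl on the Benzyl Group

The compounds below may be only part of what the source reports. "The series", "measured", "known", "first", "only" and "open" are said of these compounds alone.

Compound 1 `COc1ccccc1CN(C)CCCCn1c(=O)oc2ccccc21`: 594 nM
Compound 2 `CN(CCCn1c(=O)oc2ccccc21)Cc1ccc(Cl)cc1`: 1150 nM
Compound 3 `Cc1cccc(CN(C)CCCCn2c(=O)oc3ccccc32)c1`: 102 nM

In an assay on membranes from liver for displacement of a labelled ligand from Sigma non-opioid intracellular receptor 1 (Rattus norvegicus), read by scintillation counting (a lower number here means a stronger inhibitor, a higher number a weaker inhibitor), compound 3 stands at the lowest number of the three, and both steps to it are beyond the scatter. The only single-place step among these compounds is a 5.8-fold lower number from compound 1 to compound 3 (0.77 log units; beyond the scatter), a modest change. Compound 2 simply shows a higher number than compound 3.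

Compound 4 `Cc1ccc(CN(C)CCCCn2c(=O)oc3ccccc32)cc1` differs from compound 3 by 4-methylphenyl in place of 3-methylphenyl on a saturated chain carbon bound to an amine nitrogen. Among the compounds with values here, no measured step moves a methyl from one place on the phenyl ring to another, so nothing here directly predicts the outcome; the one step that changed the benzyl group altered both the substituent and its place. Compound 4 is therefore expected to sit close to compound 3, with a step of a 1.5-fold higher number from compound 3 to compound 4 (0.17 log units; within the scatter) that need not exceed the scatter. The estimate for compound 4 is 150 nM, in the range 50 nM to 500 nM.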

Compound 4, inhibition constant: 97 nM
Beside the measured number, compound 4's estimate is 1.5-fold (0.19 log units) above it; the range from low to high includes it.
By their numbers in this assay, from the lowest: compounds 4 and 3 (each within the scatter of the next); then compounds 1 and 2 (each within the scatter of the next).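

In this assay, the position of the methyl on this phenyl ring, on a saturated chain carbon bound to an amine nitrogen, makes no difference that can be read: the change gives a 1.1-fold lower number from compound 3 to compound 4 (0.02 log units; within the scatter). The lower number relative to 2-methoxyphenyl now holds for both methylphenyl groups, with a 6.1-fold lower number from compound 1 to compound 4 (0.79 log units; beyond the scatter). No measurement on hand explains this result.

The compounds shown do not separate the change of group from the change of place in the step from compound 1. They also leave open whether an ethyl or a trifluoromethyl group in place of the methyl of 4-methylphenyl would keep the number of compound 4.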